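Replacing a chlorophenyl with pyridinyl on a shared core

The source may report more compounds than this note shows. Statements on the series, on what has been measured and on what is new or still open speak of the compounds shown alone.

Three compounds have been tested in a functional assay on B16-F10 cells (Mus musculus) for cytotoxicity; on this read-out higher numbers stand for weaker inhibition and lower numbers for stronger inhibition:
Compound 1 `O=c1oc2ccccc2c2nc3c(ccc4cc[nH]c43)c(-c3ccc(C(F)(F)F)cc3)c12` gives 70700 nM.
Compound 2 `O=c1oc2ccccc2c2nc3c(ccc4cc[nH]c43)c(-c3cccnc3Cl)c12` gives 70700 nM.
Compound 3 `O=c1oc2ccccc2c2nc3c(ccc4cc[nH]c43)c(-c3ccc(Cl)cc3)c12` gives 70700 nM.

All three share the same core and differ only in the aromatic group hanging from it. Compound 3 stands level with the other two: the change no change at the digits printed from compound 1 to compound 3 (within the scatter) and the change no change at the digits printed from compound 2 to compound 3 (within the scatter) both lie within the scatter, as does no change at the digits printed from compound 1 to compound 2 (within the scatter). Whatever is swapped in at this position, the read-out has so far not moved.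

Compound 4 `O=c1oc2ccccc2c2nc3c(ccc4cc[nH]c43)c(-c3ccccn3)c12` continues this series with a further swap at the same place: pyridin-2-yl in place of 4-chlorophenyl on an aromatic carbon. The three measured steps all bear on this question, since each exchanged one aromatic group for another at the same carbon, and each was too small to count. Nothing in these data suggests that a pyridin-2-yl would behave differently, so the expected step of no change at the digits printed from compound 3 to compound 4 (within the scatter) is none beyond the scatter. Compound 4 is therefore estimated at 70700 nM, with a likely range from 35000 nM to 140000 nM.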

Compound 4, half-maximal inhibitory concentration: 70700 nM
Beside the measured number, compound 4's estimate shows no gap at the digits printed; the measured number falls inside the stated range.
By their numbers in this assay, from the lowest: compounds 1, 2, 3 and 4 (each within the scatter of the next).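

Going by these compounds alone, compound 4 is the first whose aromatic group carries neither a chloro nor a trifluoromethyl substituent, and in this assay the measurements show no change at the digits printed from compound 3 to compound 4 (within the scatter) and no change at the digits printed from compound 2 to compound 4 (within the scatter) and also no change at the digits printed from compound 1 to compound 4 (within the scatter). A plain pyridin-2-yl therefore reads the same here as the substituted rings, so at this aromatic carbon the substituent can be absent without any visible effect on the number. Nothing available explains why all four compounds read alike, so the flat result stands as an observation without a cause.

From the compounds shown here alone, what remains open is whether anything other than a six-membered aromatic ring at this carbon would shift the read-out, for example an amine, a carboxylic acid or a longer alkyl chain. The four compounds also share every other part of the core, so they cannot show whether a change elsewhere, such as a methyl group on the ring nitrogen that carries a hydrogen, would move this assay away from this common level.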